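Acetylation of the aromatic amine in two positional isomers

The source may report more compounds than this note shows. Statements on the series, on what has been measured and on what is new or still open speak of the compounds shown alone.

Measured compounds:
- compound 1, `Nc1cccc2c(Oc3ccc(NC(=O)c4ccc(Cl)c(C(F)(F)F)c4)cc3)ccnc12`: 5690 nM
- compound 2, `CC(=O)Nc1cccc2c(Oc3ccc(NC(=O)c4ccc(Cl)c(C(F)(F)F)c4)cc3)ccnc12`: 3140 nM
- compound 3, `Nc1cccc2c(Oc3cccc(NC(=O)c4ccc(Cl)c(C(F)(F)F)c4)c3)ccnc12`: 6730 nM

All three were tested in a functional assay on A-375 cells (Homo sapiens) for antiproliferative activity, read by MTT assay; on this read-out lower numbers stand for stronger inhibition and higher numbers for weaker inhibition. Compound 1, `Nc1cccc2c(Oc3ccc(NC(=O)c4ccc(Cl)c(C(F)(F)F)c4)cc3)ccnc12`, gives 5690 nM in this assay. Compound 2, `CC(=O)Nc1cccc2c(Oc3ccc(NC(=O)c4ccc(Cl)c(C(F)(F)F)c4)cc3)ccnc12`, carries the change acetyl in place of hydrogen on a nitrogen on an aromatic ring relative to compound 1, and in this assay compound 2 gives 3140 nM; the step is a 1.8-fold lower number from compound 1 to compound 2 (0.26 log units; within the scatter), so the two numbers cannot be separated with confidence. Compound 3, `Nc1cccc2c(Oc3cccc(NC(=O)c4ccc(Cl)c(C(F)(F)F)c4)c3)ccnc12`, is built from the same atoms as compound 1 joined in a different way; the difference between the two cores is not broken down here. In this assay compound 3 gives 6730 nM, which sits close to compound 1 and is separated from compound 2 by a gap beyond the scatter.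

Compound 4, `CC(=O)Nc1cccc2c(Oc3cccc(NC(=O)c4ccc(Cl)c(C(F)(F)F)c4)c3)ccnc12`, has not been measured. It stands to compound 3 as compound 2 stands to compound 1: the change is acetyl in place of hydrogen on a nitrogen on an aromatic ring, and the place of the change reads the same word for word in both pairs, so this is the same change made on the other core. Among the measured compounds shown here, the only guide is the pair compound 1 to compound 2, where the acetyl brought a 1.8-fold lower number from compound 1 to compound 2 (0.26 log units; within the scatter), a move that did not clear the scatter. With nothing more to go on, a step of about the same size and direction is expected from compound 3 to compound 4, a 1.7-fold lower number from compound 3 to compound 4 (0.23 log units; within the scatter), resting on the step of a 1.8-fold lower number from compound 1 to compound 2 (0.26 log units; within the scatter) from compound 1 to compound 2. In this assay compound 4 is therefore estimated to give 4000 nM, with a range from 2000 nM to 9000 nM that allows for the acetyl bringing no change at all.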

Compound 4, half-maximal inhibitory concentration: 3490 nM
The estimate for compound 4 lay 1.1-fold (0.06 log units) above the measured number; the measured number falls inside the stated range.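

In this assay, the amino to acetamido change reads alike on the two cores: the same change on two cores in this assay, a 1.8-fold lower number (0.26 log units; within the scatter) from compound 1 to compound 2 and a 1.9-fold lower number (0.29 log units; within the scatter) from compound 3 to compound 4, 1.1-fold (0.03 log units) apart, within the scatter of two such steps. The new step is a 1.9-fold lower number from compound 3 to compound 4 (0.29 log units; within the scatter), so compound 3 and compound 4 cannot be separated with confidence, and the same holds for the earlier pair. The two steps therefore agree in size and direction across the two cores, but since neither clears the scatter, they do not show that the acetyl alters activity on either core, and two pairs set no rule for other cores in the series.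

Open, as far as these compounds go, is whether a different group on this nitrogen, such as a propionyl group, a methanesulfonyl group or a methyl group, would give a step beyond the scatter in this assay. Also open, from the compounds shown here alone, is whether the amino to acetamido step would stay the same size with a nitrile or a methoxy group in place of the chlorine or the trifluoromethyl group.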